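The source may report more compounds than this note shows. Statements on the series, on what has been measured and on what is new or still open speak of the compounds shown alone.

Measured so far:
- compound 1, `CCCCC#Cc1cc2cn([C@@H]3O[C@H](CO)[C@@H](O)[C@H]3O)c(=O)nc2o1`: > 144000 nM
- compound 2, `CCCCC#Cc1cc2cn(C)c(=O)nc2o1`: >= 217000 nM

Both readings come from a functional assay on HEL cells (Homo sapiens) for cytotoxicity; a lower number here means that less compound is tolerated, a higher number that more compound is tolerated. For compound 1 the value is a limit of the assay, not a number (the limit of > 144000 nM in this assay, at which 1 of the 2 values shown sits). For compound 2 the reading is likewise a limit (the limit of >= 217000 nM in this assay, at which 1 of the 2 values shown sits). Among the compounds with values here, compound 1 therefore stands at a limit, and the only other value shown is a limit as well; nothing in these two readings separates the compounds, and no step between them has been worked out.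

Compound 3, `CCCCCCC#Cc1cc2cn([C@@H]3O[C@H](CO)[C@@H](O)[C@H]3O)c(=O)nc2o1`, has not yet been measured in this assay. It differs from compound 1 in one place: ethyl in place of hydrogen on a saturated chain carbon, four bonds along the chain from a triple-bonded carbon. The rest of compound 1 is unchanged, and only the saturated chain grows longer.

Within the data shown here, with no measured step to lean on, the expected change from compound 1 to compound 3 is none beyond the scatter, a number no higher from compound 1 to compound 3 (the limit leaves the size open). Compound 3 is therefore expected to come in at about 144000 nM, within a range from 50000 nM to 300000 nM, and it is expected that the assay will most likely again report only a limit rather than a number.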

Compound 3, minimum cytotoxic concentration: >= 133000 nM
Compound 3: only a limit was reported; the forecaster's own chance of this, stated with the estimate: 70%; the middle value lies beyond the limit too.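

In this assay compound 3 gives >= 133000 nM, which is a limit of the assay and not a number. Compound 1 also stands at a limit, so no step can be read from compound 1 to compound 3. The compounds shown leave open the concentration at which any of them harms these cells, and whether ethyl in place of hydrogen changes it.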